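Halogen swap in a quinoline hydrazone series

The source may report more compounds than this note shows. Statements on the series, on what has been measured and on what is new or still open speak of the compounds shown alone.

Measured so far in a functional assay on MDA-MB-231 cells (Homo sapiens) for cytotoxicity, read by MTT assay, with a stated time of 48 h; on this read-out higher numbers stand for weaker inhibition and lower numbers for stronger inhibition:
Compound 1 `Nc1nc(-c2ccc(Cl)cc2)cn1/N=C/c1cc2ccccc2nc1Cl` gives > 50000 nM, a limit of the assay rather than a number.
Compound 2 `Nc1nc(-c2ccc(Br)cc2)cn1/N=C/c1cc2ccccc2nc1Cl` gives > 50000 nM, again a limit of the assay.
Compound 3 `Cc1ccc2nc(Cl)c(/C=N/n3cc(-c4ccc(Cl)cc4)nc3N)cc2c1` gives 35200 nM.

Compound 1 and compound 2 share one core and differ only by bromo in place of chloro on an aromatic carbon. Both sit at the limit of > 50000 nM in this assay, at which 2 of the 3 values shown sit, so the step that the two limits leave unreadable from compound 1 to compound 2. Compound 3 carries a second core, set apart from that of compound 1 by methyl in place of hydrogen on an aromatic carbon; the step of an at least 1.4-fold lower number from compound 1 to compound 3 (0.15 log units; that floor lies within the scatter).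

Compound 4 `Cc1ccc2nc(Cl)c(/C=N/n3cc(-c4ccc(Br)cc4)nc3N)cc2c1` has not yet been measured in this assay. For the measured compounds named here, it stands to compound 3 as compound 2 stands to compound 1: the change is bromo in place of chloro on an aromatic carbon, the same change as the one from compound 1 to compound 2, since the two place descriptions read alike word for word. The size of that change is not readable from the first pair, because both of its members sit at the limit of > 50000 nM in this assay, at which 2 of the 3 values shown sit, and it is the only other occurrence among these compounds. Going by the values given here, the expectation for compound 4 therefore rests on compound 3 alone, whose value 35200 nM is the single number available, and on the first pair giving no sign that the swap moves the read-out far. The expected step is a 1.1-fold higher number from compound 3 to compound 4 (0.03 log units; within the scatter), within the scatter. Compound 4 is expected to give about 38000 nM, with a range from 15000 nM to 90000 nM, and a real chance that only a limit is reported.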

Compound 4, half-maximal inhibitory concentration: 38200 nM
The estimate for compound 4 lay 1.0-fold (0.00 log units) below the measured number; low and high end bracket the measured number.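

In this assay, the change from 4-chlorophenyl to 4-bromophenyl on the core of compound 3 is a 1.1-fold higher number from compound 3 to compound 4 (0.04 log units; within the scatter), so on this core the swap shows no difference that can be told from the scatter. The same swap on the core of compound 1 cannot be read, and the data therefore do not show that the result carries from one core to the other, only that nothing shown speaks against it, because both members of the first pair stand at a limit: the limit of > 50000 nM in this assay, at which 2 of the 4 values shown sit.

Methyl in place of hydrogen now appears as an at least 1.3-fold lower number from compound 2 to compound 4 (0.11 log units; that floor lies within the scatter), which is only a floor, and set beside the earlier step it gives no measured size on either core and no test of whether the change carries over: the same change on two cores in this assay, an at least 1.4-fold lower number (0.15 log units; that floor lies within the scatter) from compound 1 to compound 3 and an at least 1.3-fold lower number (0.11 log units; that floor lies within the scatter) from compound 2 to compound 4; the limit leaves it open whether they differ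

The compounds shown leave open how the read-out responds when the chloro or bromo gives way to a different kind of group, such as a methoxy group or a carboxylic acid. Also open, from the compounds shown here alone, is whether an amine or a longer chain in place of the methyl would give a number beyond the scatter of those seen in this assay.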